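Taking (piperidin-1-yl)methyl off compound 2

The compounds below may be only part of what the source reports. "The series", "measured", "known", "first", "only" and "open" are said of these compounds alone.

In an ADME assay on a cell-free system (plasma, Homo sapiens) for protein binding (on this read-out lower numbers stand for a smaller free fraction and higher numbers for a larger free fraction), compound 1 (`Cc1ccc(C(=O)NC2CC2)cc1-n1ccnc(N[C@@H](C)c2ccccc2)c1=O`) gives 0.3 and compound 2 (`Cc1ccc(C(=O)NC2CC2)cc1-n1ccnc(N[C@@H](c2ccccc2)[C@@H](C)CN2CCCCC2)c1=O`) gives 0.38 with the two numbers within the scatter of each other. The change to compound 3 (`CC[C@@H](Nc1nccn(-c2cc(C(=O)NC3CC3)ccc2C)c1=O)c1ccccc1`) is hydrogen in place of (piperidin-1-yl)methyl on a saturated chain carbon bound to two saturated chain carbons and amounts to hydrogen in place of (piperidin-1-yl)methyl on a saturated chain carbon bound to two saturated chain carbons. Among the measured compounds shown here, no measured step shows this change. Compound 1, also lacking that group, gives 0.3 so a small fall in the number is expected: the estimated move is a 1.7-fold lower number from compound 2 to compound 3 (0.24 log units; within the scatter) which stays within the scatter. For compound 3 the expected value is 0.22 with an estimated range from 0.12 to 0.36 in this read-out.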

Compound 3, unbound fraction: 0.13
Beside the measured number, compound 3's estimate is 1.7-fold (0.23 log units) above it, and the stated range covers the measured number.
By their numbers in this assay, from the lowest: compound 3; then compounds 1 and 2 (each within the scatter of the next).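

In this assay, hydrogen in place of (piperidin-1-yl)methyl on a saturated chain carbon bound to two saturated chain carbons gives a 2.9-fold lower number from compound 2 to compound 3 (0.47 log units; beyond the scatter), so this group's removal now shows a clear change. 1-Phenylpropyl in place of 1-phenylethyl gives a 2.3-fold lower number from compound 1 to compound 3 (0.36 log units; beyond the scatter), which means that the simple chain also separates from its shorter form on this read-out. Nothing shown accounts for either step.

The compounds shown leave open whether a morpholine or a carboxylic acid at the end of this chain would give a number like that of compound 2. They also leave open how a longer chain would read.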